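This account rests on a few compounds, and the source may have more. Where it says the series, first, only, none or still open, it means among the compounds named here.

Measured compounds:
compound 1 `C=C1[C@@H](OC(C)=O)C[C@@H]2[C@](C)(CO[Si](C)(C)C(C)(C)C)[C@H](OC(C)=O)CC[C@@]2(C)[C@@H]1C[C@@H](Nc1ccc(OC)cc1)C1=CCOC1=O` gives 4810 nM
compound 2 `C=C1[C@@H](OC(C)=O)C[C@@H]2[C@](C)(COC=O)[C@H](OC(C)=O)CC[C@@]2(C)[C@@H]1C[C@@H](Nc1ccc(O)cc1)C1=CCOC1=O` gives 29100 nM
compound 3 `C=C1[C@@H](OC(C)=O)C[C@@H]2[C@](C)(CO[Si](C)(C)C(C)(C)C)[C@H](OC(C)=O)CC[C@@]2(C)[C@@H]1C[C@@H](Nc1cccc(F)c1)C1=CCOC1=O` gives 4060 nM

These three were tested in a functional assay on A549 cells (Homo sapiens) for cytotoxicity, read by sulforhodamine B assay; on this read-out lower numbers stand for stronger inhibition and higher numbers for weaker inhibition. Compound 2 stands at the highest number of the three, with compound 1 nearest and compound 3 furthest, and both gaps lie beyond the scatter. Compound 2 differs from compound 1 and from compound 3 not only in the group on the amine nitrogen but also in the side chain on the shared core, so its position cannot be laid at the door of the aryl group alone.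

The unmeasured compound 4 `C=C1[C@@H](OC(C)=O)C[C@@H]2[C@](C)(COC=O)[C@H](OC(C)=O)CC[C@@]2(C)[C@@H]1C[C@@H](Nc1ccccc1F)C1=CCOC1=O` keeps the side chain of compound 2 and changes only the aryl group: 2-fluorophenyl in place of 4-hydroxyphenyl on an amine nitrogen

Among the compounds with values here, the one measured step that swaps an aryl group on this nitrogen, a 1.2-fold lower number from compound 1 to compound 3 (0.07 log units; within the scatter), was within the scatter, although it exchanged different groups and sat on a different side chain. Within the data shown here, no measured step exchanges a hydroxyphenyl for a fluorophenyl. The expectation is therefore a movement no larger than modest, if any, and the direction is uncertain; the estimate leans slightly toward a lower number, a 1.6-fold lower number from compound 2 to compound 4 (0.21 log units; within the scatter). Compound 4 is estimated at 18000 nM, within a range of 6000 nM to 50000 nM.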

Compound 4, half-maximal inhibitory concentration: 23600 nM
The estimate for compound 4 lay 1.3-fold (0.12 log units) below the measured number, within the range that was stated.
By their numbers in this assay, from the lowest: compounds 3 and 1 (each within the scatter of the next); then compounds 4 and 2 (each within the scatter of the next).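

In this assay, the side chain shared by compound 2 and compound 4 tolerates this exchange on the amine nitrogen: a 1.2-fold lower number from compound 2 to compound 4 (0.09 log units; within the scatter). The group that leaves has a hydrogen-bond donor and a hydrogen-bond acceptor and the group that enters has neither, yet this count changes with no shift in the number beyond the scatter, and the earlier aryl exchange, a 1.2-fold lower number from compound 1 to compound 3 (0.07 log units; within the scatter), was also within the scatter on a different side chain. No measurement on hand explains why this position responds so little to either exchange.

The compounds shown leave open what the side chain itself contributes, since no two of them differ in that place alone, so the separate effect of replacing the silyl ether side chain with the one in compound 2 and compound 4 cannot be read. They also leave open whether a group of another kind on the amine nitrogen, such as a cyclohexyl ring or a phenyl ring bearing a carboxylic acid, would move the number beyond the scatter.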